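The source may report more compounds than this note shows. Statements on the series, on what has been measured and on what is new or still open speak of the compounds shown alone.

- compound 1 `CO[C@H]1O[C@H](COc2ccc(-c3ccccc3)cc2)[C@@H](O)[C@H](O)[C@H]1Oc1ccccc1` with 36000 nM
- compound 2 `CO[C@H]1O[C@H](COc2ccc(C3CCCCC3)cc2)[C@@H](O)[C@H](O)[C@H]1Oc1ccc(OC2CCCCC2)cc1` with 12000 nM

In a functional assay on A549 cells (Homo sapiens) for cytotoxicity, read by MTT assay, with a stated time of 48 h (on this read-out lower numbers stand for an effect already at smaller amounts and higher numbers for an effect only at larger amounts of compound), compound 1 stands highest of the two, at 36000 nM on this scale, so it needs the larger amount to show an effect. Compound 2 sits at 12000 nM and the gap between the two lies beyond the usual scatter.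

The next compound to be tested, compound 3 `CO[C@H]1O[C@H](COc2ccc(-c3ccccc3)cc2)[C@@H](O)[C@H](O)[C@H]1Oc1ccccc1C(C)C`, keeps the core of compound 1 and changes one place. The phenoxy group becomes 2-isopropylphenoxy, with isopropyl in place of hydrogen on an aromatic carbon, ortho to a large group isopropyl in place of hydrogen on an aromatic carbon in the structure. Among the compounds with values here, no measured pair isolates a change like this, so the expectation rests on thin evidence. Within the data shown here, the only hint is that compound 2, which also carries an added group on its phenoxy part, gives 12000 nM in the same test. In this assay the expected result is a small step of a 1.6-fold lower number from compound 1 to compound 3 (0.21 log units; within the scatter) toward a lower number, one that may stay within the usual scatter. For compound 3 the estimated value is 22000 nM with an expected range from 9000 nM to 50000 nM overall.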

Compound 3, half-maximal effective concentration: 33000 nM
Estimate against measurement, compound 3: 1.5-fold (0.18 log units) below, within the range that was stated.
By their numbers in this assay, from the lowest: compound 2; then compounds 3 and 1 (each within the scatter of the next).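

In this assay, putting isopropyl in place of hydrogen on an aromatic carbon of the phenoxy group, ortho to a large group, gives a 1.1-fold lower number from compound 1 to compound 3 (0.04 log units; within the scatter), so this change leaves the two compounds indistinguishable on this read-out. This is the first pair among the compounds shown that differs in one place, and it shows that this position can carry a branched isopropyl group without a measurable shift in the cytotoxicity reading. Nothing measured here explains why the reading holds steady, and this single pair offers no information on how the compounds act in these cells.

Isopropyl is the only group shown at this position, so it remains open whether an amine, a carboxylic acid or a longer chain on the same aromatic carbon would also leave the reading in place. One pair also cannot show whether the same swap of hydrogen for isopropyl would give a similar result on a different set of groups around the shared core.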